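Dropping a chloro on a dioxane-free peroxide core: expected effect

The source may hold more compounds than are shown below. What is called first, only, known or untested is meant among the compounds shown, and "the series" means these compounds.

Of the compounds shown here, three have been measured in a functional assay on L02 cells (Homo sapiens) for inhibition, read by MTT assay, with a stated time of 72 h; on this read-out lower numbers stand for stronger inhibition and higher numbers for weaker inhibition. Compound 1 `C=C(c1ccc(Cl)c(Cl)c1)C1COC(C)(C)OO1` gives 50900 nM. Compound 2 `C=C(c1ccc(Cl)c(Cl)c1Cl)C1COC(C)(C)OO1` gives 18100 nM. Compound 3 `C=C(c1ccc(Cl)c(Cl)c1Cl)C1COC2(CCCCC2)OO1` gives 1220 nM, the lowest of the three numbers. The difference between the core of compound 2 and the core of compound 3 is not broken down here.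

One structural change has already been measured once. Going from compound 2 to compound 1 is the change (hydrogen in place of chloro on an aromatic carbon), and it made a 2.8-fold higher number from compound 2 to compound 1 (0.45 log units; beyond the scatter).

Compound 4 `C=C(c1ccc(Cl)cc1Cl)C1COC2(CCCCC2)OO1` has not yet been measured. It differs from compound 3 by hydrogen in place of chloro on an aromatic carbon. This is the same kind of change as between compound 2 and compound 1, but not the same: here the hydrogen enters ortho to two chloro groups and meta to a large group, whereas before it entered ortho to a chloro group, ortho to a large group and meta to a chloro group.

Because a 2.8-fold higher number from compound 2 to compound 1 (0.45 log units; beyond the scatter) was modest, a step of similar size is expected for compound 4, namely a 2.6-fold higher number from compound 3 to compound 4 (0.42 log units; beyond the scatter). In this assay compound 4 is therefore estimated at 3200 nM, likely between 1200 nM and 8500 nM.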

Compound 4, half-maximal inhibitory concentration: 3690 nM
For compound 4 the middle estimate is 1.2-fold (0.06 log units) below the measured one; low and high end bracket the measured number.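

In this assay, putting hydrogen in place of a chloro on the aromatic ring gave a 3.0-fold higher number from compound 3 to compound 4 (0.48 log units; beyond the scatter), and this step agrees with the earlier one on the other core: the same change on two cores in this assay, a 2.8-fold higher number (0.45 log units; beyond the scatter) from compound 2 to compound 1 and a 3.0-fold higher number (0.48 log units; beyond the scatter) from compound 3 to compound 4, 1.1-fold (0.03 log units) apart, within the scatter of two such steps. This shows that, in these two pairs, losing one chloro from the ring changed the number by a similar modest amount on both cores. It does not show a general rule, as two pairs are a small sample and the chloro did not leave from the same place: in compound 3 it sat ortho to two chloro groups and meta to a large group, whereas in compound 2 it sat ortho to a chloro group and ortho to a large group.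

The compounds shown leave open what happens when a group other than hydrogen, such as a methoxy group or an amine, takes the place of the chloro. Also open, on these data alone, is whether removing a chloro from one and the same place on both cores would give a matching step.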